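Shifting the Methyl Group: Compound 2 to Compound 3

This account rests on a few compounds, and the source may have more. Where it says the series, first, only, none or still open, it means among the compounds named here.

Compound 1 `O=C(NCc1ccc(CNS(=O)(=O)c2ccccc2)cc1)c1ccccc1F`: 1000 nM
Compound 2 `Cc1ccccc1C(=O)NCc1ccc(CNS(=O)(=O)c2ccccc2)cc1`: 1 nM

In an assay on MDA-MB-231 cells for binding affinity to C-X-C chemokine receptor type 4 (Homo sapiens), read by immunofluorescence and microscopy, with stated times of 10 min and 30 min (on this read-out lower numbers stand for an effect already at smaller amounts and higher numbers for an effect only at larger amounts of compound), compound 2 gives 1 nM, the lowest of the two numbers, while compound 1 gives 1000 nM. Going by the values given here, the single measured step, a 1000-fold lower number from compound 1 to compound 2 (3.00 log units; beyond the scatter), swaps a fluoro for a methyl at the same place. Compound 3 `Cc1ccc(C(=O)NCc2ccc(CNS(=O)(=O)c3ccccc3)cc2)cc1` instead carries 4-methylphenyl in place of 2-methylphenyl on a carbonyl carbon. Among the compounds with values here, no measured step moves a methyl from one place on this ring to another, so the large step between compound 1 and compound 2 bears on it only loosely. Some weakening is expected, giving a 20-fold higher number from compound 2 to compound 3 (1.30 log units; beyond the scatter). Compound 3 is therefore estimated at 20 nM, with a range of 2 nM to 300 nM.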

Compound 3, effective concentration (reported as EC, without a stated level of effect): 100 nM
The estimate for compound 3 lay 5.0-fold (0.70 log units) below the measured number, and the stated range covers the measured number.
By their numbers in this assay, from the lowest: compound 2; then compound 3; then compound 1.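

Moving the methyl around the ring, with no atom gained or lost, gives a 100-fold higher number from compound 2 to compound 3 (2.00 log units; beyond the scatter), so where the methyl sits matters as well as whether it is present. Even so, 4-methylphenyl in place of 2-fluorophenyl gives a 10-fold lower number from compound 1 to compound 3 (1.00 log units; beyond the scatter), so part of the gain seen with the methyl survives the move. Nothing available explains this dependence on placement.

From the compounds shown here alone, it remains open whether an ethyl group or an amine in place of the methyl of 2-methylphenyl would keep the low number of compound 2.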